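Swapping 2-bromophenyl for 4-hydroxyphenyl on a shared core

The source may hold more compounds than are shown below. What is called first, only, known or untested is meant among the compounds shown, and "the series" means these compounds.

- Compound 1 `COc1ccccc1/C=C1\CCC/C(=C\c2cccc(OC)c2OC)C1=O`: 14100 nM
- Compound 2 `COc1cccc(/C=C2\CCC/C(=C\c3cccc(Cl)c3Cl)C2=O)c1OC`: 19300 nM
- Compound 3 `COc1ccc(/C=C2\CCC/C(=C\c3ccccc3Br)C2=O)cc1OC`: 8400 nM

In a functional assay on HT-1080 cells (Homo sapiens) for cytotoxicity, read by MTT assay, with a stated time of 72 h (a higher number here means a weaker inhibitor, a lower number a stronger inhibitor), compound 3 gives 8400 nM. That lies within the scatter of compound 1 and beyond it only against compound 2.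

Compound 4 `COc1ccc(/C=C2\CCC/C(=C\c3ccc(O)cc3)C2=O)cc1OC` has 4-hydroxyphenyl in place of 2-bromophenyl on a double-bonded chain carbon bound to a double-bonded ring carbon.

One measured step exchanges a group at this place, a 1.4-fold higher number from compound 1 to compound 2 (0.14 log units; within the scatter), and it stayed within the scatter. For the measured compounds named here, no measured compound carries 4-hydroxyphenyl, so the data suggest no direction, and no step beyond the scatter is expected in this assay.

The expected change is small, an estimated 1.1-fold higher number from compound 3 to compound 4 (0.03 log units; within the scatter).

For compound 4 the estimate is 9000 nM, with an expected range of 3500 nM to 23000 nM.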

Compound 4, half-maximal inhibitory concentration: 16800 nM
Compound 4: middle estimate off by 1.9-fold (0.27 log units), on the low side, and the stated range covers the measured number.
By their numbers in this assay, from the lowest: compounds 3, 1, 4 and 2 (each within the scatter of the next, the first and the last beyond it).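

The change gives a 2.0-fold higher number from compound 3 to compound 4 (0.30 log units; within the scatter) in this assay and so stays within the scatter, even though 4-hydroxyphenyl has a hydrogen-bond donor and acceptor and 2-bromophenyl has neither. This is the second exchange at this place to stay within the scatter, and the first to bring in a hydroxyl group. Nothing available explains the numbers at this place.

Still open, on these data alone, is whether a phenyl ring carrying an amine or a carboxylic acid would move the number beyond the scatter here.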